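A second chlorine on the benzyl arm of compound 1

The compounds below may be only part of what the source reports. "The series", "measured", "known", "first", "only" and "open" are said of these compounds alone.

Measured so far:
compound 1, `CCN(CC)Cc1ccc2nc(NC(=O)N/N=C/c3cn(Cc4ccccc4Cl)c4ccccc34)sc2c1`, 900 nM
compound 2, `CN(C)Cc1ccc2nc(NC(=O)N/N=C/c3cn(Cc4ccccc4Cl)c4ccccc34)sc2c1`, 1180 nM
compound 3, `CN(C)Cc1ccc2nc(NC(=O)N/N=C/c3cn(Cc4ccccc4)c4ccccc34)sc2c1`, 1340 nM

These three compounds share one core and were all tested in a functional assay on MDA-MB-231 cells (Homo sapiens) for cytotoxicity, read by MTT assay, with a stated time of 72 h; a higher number here means a weaker inhibitor, a lower number a stronger inhibitor. Compound 1 gives the lowest number of the three, but the gaps to compound 2 and to compound 3 are both within the scatter, so no one of them can be called the stronger inhibitor. The step of a 1.3-fold higher number from compound 1 to compound 2 (0.12 log units; within the scatter) changes only the amine on the other end of the molecule. The step of a 1.1-fold higher number from compound 2 to compound 3 (0.06 log units; within the scatter) removes the chlorine from the benzyl group, and even that leaves the number within the scatter.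

Compound 4, `CCN(CC)Cc1ccc2nc(NC(=O)N/N=C/c3cn(Cc4ccc(Cl)c(Cl)c4)c4ccccc34)sc2c1`, has not yet been measured. It differs from compound 1 in one place: 3,4-dichlorophenyl in place of 2-chlorophenyl on a saturated chain carbon bound to an aromatic nitrogen. Among the measured compounds shown here, the step that bears most closely on this is the one from compound 2 to compound 3, which touched the same benzyl group and produced nothing beyond the scatter; the other step lies elsewhere. Moving chlorine around on this ring, or removing it, has so far not mattered, so the expected step of no change at the digits printed from compound 1 to compound 4 (within the scatter) is none beyond the scatter. Compound 4 is therefore estimated at 900 nM, within a range of 400 nM to 2000 nM.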

Compound 4, half-maximal inhibitory concentration: 4490 nM
The estimate for compound 4 lay 5.0-fold (0.70 log units) below the measured number, outside the stated range (above it).
By their numbers in this assay, from the lowest: compounds 1, 2 and 3 (each within the scatter of the next); then compound 4.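

In this assay, replacing 2-chlorobenzyl with 3,4-dichlorobenzyl on the saturated chain carbon bound to an aromatic nitrogen gives a 5.0-fold higher number from compound 1 to compound 4 (0.70 log units; beyond the scatter) and so a weaker inhibitor. This shows that the benzyl arm is not indifferent to what it carries, which the earlier step on this arm could not show: removing the chlorine gave only a 1.1-fold higher number from compound 2 to compound 3 (0.06 log units; within the scatter) on a compound with dimethylamino at the other end of the molecule. The new step changes how many chlorines the ring carries and where they sit in a single move, so it cannot separate the two changes, and no measurement shown here accounts for the loss.

The compounds shown leave open whether the extra chlorine or its placement matters more, and whether a fluorine or a methoxy group in place of chlorine on this ring would give a similar number. They also leave open whether the 3,4-dichlorobenzyl arm would give a step of similar size on a compound that carries dimethylamino in place of diethylamino.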